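This account rests on a few compounds, and the source may have more. Where it says the series, first, only, none or still open, it means among the compounds named here.

Working notes on the series.

Compound 2 `COc1cccc(OC)c1C(=O)Nc1nnc(-c2ccc([N+](=O)[O-])cc2)s1` carries the shared core of compound 1 `COc1cccc(OC)c1C(=O)Nc1nnc(-c2ccc(C)cc2)s1`. Among the measured compounds shown here, in a functional assay on the whole organism (integument) for inhibition, with Chilo suppressalis as the target, read by scintillation counting, with a stated time of 72 h, in the presence of a further agent that is not named here (a lower number here means a stronger inhibitor, a higher number a weaker inhibitor), compound 2 gives 269 nM, the higher of the two numbers measured so far; compound 1 gives 85.1 nM. For the measured compounds named here, the single measured step is a 3.2-fold higher number from compound 1 to compound 2 (0.50 log units; beyond the scatter), a modest move beyond the scatter.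

Compound 3 `COc1cccc(OC)c1C(=O)Nc1nnc(-c2ccc(-c3ccccc3)cc2)s1` is the next member. The change from compound 2 is phenyl in place of nitro on an aromatic carbon; the group sits on an aromatic carbon of a six-membered aromatic ring of carbon only, para to a large group. Going by the values given here, no measured pair shows phenyl against nitro or phenyl against methyl at this position, so the only step that bears on it is the one from compound 1 to compound 2, which shows that exchanging the group at this carbon moves the number by a modest amount rather than leaving it flat. On that basis the expected step in this assay is a 2.1-fold lower number from compound 2 to compound 3 (0.32 log units; beyond the scatter), toward a lower number, with wide uncertainty in either direction.

Compound 3 is therefore estimated at 130 nM in this assay, with a range from 40 nM to 400 nM.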

Compound 3, half-maximal inhibitory concentration: 117 nM
Beside the measured number, compound 3's estimate is 1.1-fold (0.05 log units) above it; the range from low to high includes it.
By their numbers in this assay, from the lowest: compounds 1 and 3 (each within the scatter of the next); then compound 2.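

In this assay the exchange of nitro for phenyl on this carbon gives a 2.3-fold lower number from compound 2 to compound 3 (0.36 log units; beyond the scatter), a modest step beyond the scatter, so the step seen with nitro in place of methyl is not confined to that one pair of groups. Phenyl in place of methyl gives a 1.4-fold higher number from compound 1 to compound 3 (0.14 log units; within the scatter), which lies within the scatter, so these two groups cannot be told apart here, and nitro alone stands apart, with its steps to both compound 1 and compound 3 beyond the scatter. Nothing available accounts for these steps or says what sets nitro apart from methyl and phenyl.

The compounds shown hold only three groups at this carbon on the shared core, so it stays open whether an amine or a carboxylic acid would fall with nitro or with methyl and phenyl. As far as these compounds go, a longer chain such as butyl, or a chlorine atom, is equally open, and so is whether any group here would give a number clearly lower than those of compound 1 and compound 3.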